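A few compounds are considered here, and "the series" means these few. Any claim that something is new, unique, unknown or untested is made for them only; others in the source may bear on it.

Measured compounds and their results:

- Compound 2 `COc1ccc(/C=C\C(=O)O)c(OCc2cn(-c3ccccc3)nn2)c1CC=C(C)C`: 29200 nM
- Compound 3 `COc1ccc(/C=C\C(=O)O)c(OCc2cn(-c3ccc(CO)cc3)nn2)c1CC=C(C)C`: 27100 nM
- Compound 1 `COc1ccc(/C=C\C(=O)O)c(OCc2cn(-c3ccccc3C(=O)N3CCC(O)C3)nn2)c1CC=C(C)C`: "not determined" (no result reported)

In a functional assay on NCI-H322 cells (Homo sapiens) for cytotoxicity, read by MTT assay, with a stated time of 24 h (a lower number here means a stronger inhibitor, a higher number a weaker inhibitor), compound 2 gives 29200 nM, the highest of the two numbers available, while compound 3 gives 27100 nM. For the measured compounds named here, the only single-point change measured so far, a 1.1-fold lower number from compound 2 to compound 3 (0.03 log units; within the scatter), adds a hydroxymethyl group to the outer benzene ring; it sits within the usual scatter, so the two compounds are not distinguishable on these data. Compound 1, which carries a much larger substituent on the same ring, has no reported number.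

Compound 4 `COc1ccc(/C=C\C(=O)O)c(OCc2cn(-c3cccc(C#N)c3)nn2)c1CC=C(C)C` differs from compound 2 by cyano in place of hydrogen on an aromatic carbon. This is a small addition on the same outer ring that was varied between compound 2 and compound 3, and that earlier step changed nothing beyond the scatter. Going by the values given here, no measured step involves a cyano group, so the expectation can rest only on the one comparable change. Compound 4 is therefore expected to give a number close to that of compound 2 in this assay, with the step of a 1.0-fold lower number from compound 2 to compound 4 (0.02 log units; within the scatter) estimated to lie within the scatter. The estimate for compound 4 is 28000 nM, with a range from 14000 nM to 56000 nM.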

Compound 4, half-maximal inhibitory concentration: 26500 nM
The estimate for compound 4 lay 1.1-fold (0.02 log units) above the measured number, and the stated range covers the measured number.
By their numbers in this assay, from the lowest: compounds 4, 3 and 2 (each within the scatter of the next).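

In this assay, going from phenyl to 3-cyanophenyl gives a 1.1-fold lower number from compound 2 to compound 4 (0.04 log units; within the scatter) on the outer ring, so a second kind of small group at this ring also leaves the number within the scatter. The swap of 4-(hydroxymethyl)phenyl for 3-cyanophenyl gives a 1.0-fold lower number from compound 3 to compound 4 (0.01 log units; within the scatter) in the same assay, and here both the group and its place on the ring differ, yet this step also stays within the scatter. Compounds 2, 3 and 4 therefore cannot be told apart in this assay, and no separate measurement is available to explain why their numbers stay so close.

On these data alone, what remains open is whether any group on this outer ring can move the number beyond the scatter, for example an amine or a longer chain such as a butyl group. As far as these compounds go, it is also open whether the cyano group would give the same result at another place on the ring, since compound 4 shows it at only one.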